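Hexyl in place of fluoro on the shared core

This account rests on a few compounds, and the source may have more. Where it says the series, first, only, none or still open, it means among the compounds named here.

In a functional assay on MDA-MB-231 cells (Homo sapiens) for antiproliferative activity, with a stated time of 4 days (on this read-out higher numbers stand for weaker inhibition and lower numbers for stronger inhibition), compound 1 (`COc1ccc(-c2[nH]c3ccc(F)cc3c2C=O)cc1`) gives 540 nM as the starting point, and compound 2 (`COc1ccc(-c2[nH]c3ccc(C(C)(C)C)cc3c2C=O)cc1`) gives 280 nM on the same read-out. Among the compounds with values here, these two numbers do not separate: the only measured step is a 1.9-fold lower number from compound 1 to compound 2 (0.29 log units; within the scatter) and it comes from tert-butyl in place of fluoro on an aromatic carbon.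

Compound 3 (`CCCCCCc1ccc2[nH]c(-c3ccc(OC)cc3)c(C=O)c2c1`) carries the next change, hexyl in place of fluoro on an aromatic carbon. Within the data shown here, the tert-butyl step is the sole guide, and no measured compound holds a hexyl group, so it carries over only loosely. A step in this assay that stays within the scatter is therefore expected, with a slight lean towards a lower number, as seen in the step to compound 2 at 280 nM in the same read-out. The expected step is a 1.5-fold lower number from compound 1 to compound 3 (0.19 log units; within the scatter) by this estimate. For compound 3 the estimated value is 350 nM with an expected range from 100 nM to 1200 nM on this basis.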

Compound 3, half-maximal inhibitory concentration: 7.4 nM
Compound 3: the middle estimate sits 47-fold (1.67 log units) above what was measured, and the stated range ends above it.
By their numbers in this assay, from the lowest: compound 3; then compounds 2 and 1 (each within the scatter of the next).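

In this assay, this position on the shared core, an aromatic carbon of a six-membered aromatic ring of carbon only, proves able to move the read-out far: hexyl in place of fluoro gives a 73-fold lower number from compound 1 to compound 3 (1.86 log units; beyond the scatter), and hexyl in place of tert-butyl gives a 38-fold lower number from compound 2 to compound 3 (1.58 log units; beyond the scatter). The earlier pair gave no sign of this, since tert-butyl in place of fluoro gave only a 1.9-fold lower number from compound 1 to compound 2 (0.29 log units; within the scatter), so the size of the response appears only with the hexyl group, which separates from both earlier groups beyond the scatter. Nothing available explains the gain, so it stands as an observation on this series alone.

With only fluoro, tert-butyl and hexyl at this position, the compounds shown cannot say whether the gain follows chain length, whether it peaks at hexyl, or whether a shorter butyl chain or a longer octyl chain would hold it. They also leave open whether the gain survives an amine or a carboxylic acid at the end of the hexyl chain, and whether it carries over to any change elsewhere on the shared core.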